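Swapping methyl for chloro on the benzyl ring

The source may report more compounds than this note shows. Statements on the series, on what has been measured and on what is new or still open speak of the compounds shown alone.

Two compounds share one core and differ only in the ring hanging from the benzylic oxygen. Compound 1 `COc1cccc(COc2ccc(C3=NN(CCC#N)C(=O)CO3)cc2)c1` carries a 3-methoxyphenyl there and gives 68 nM in an assay for inhibition of Amine oxidase [flavin-containing] B (Rattus norvegicus); on this read-out lower numbers stand for stronger inhibition and higher numbers for weaker inhibition. For the measured compounds named here, compound 2 `Cc1ccc(COc2ccc(C3=NN(CCC#N)C(=O)CO3)cc2)cc1` carries a 4-methylphenyl instead and gives 320 nM in this assay, the higher of the two numbers recorded so far; the only measured step, a 4.7-fold higher number from compound 1 to compound 2 (0.67 log units; beyond the scatter), is a modest weakening. Compound 3 `N#CCCN1N=C(c2ccc(OCc3ccc(Cl)cc3)cc2)OCC1=O` is the next variation: chloro in place of methyl on an aromatic carbon. Going by the values given here, no measured step covers this exchange, since the single step known changes both the group and where it sits, so the size and direction of the effect remain open. Among the compounds with values here, with only that weak guide, the expectation for compound 3 is a number close to that of compound 2, the step of a 1.6-fold lower number from compound 2 to compound 3 (0.20 log units; within the scatter) being small and likely within the scatter. The estimate for compound 3 is therefore 200 nM, with a range from 50 nM to 700 nM.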

Compound 3, half-maximal inhibitory concentration: 100 nM
Beside the measured number, compound 3's estimate is 2.0-fold (0.30 log units) above it, and the stated range covers the measured number.
By their numbers in this assay, from the lowest: compounds 1 and 3 (each within the scatter of the next); then compound 2.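

Exchanging methyl for chloro on an aromatic carbon, para to a large group, changes the result in this assay beyond the scatter (a 3.2-fold lower number from compound 2 to compound 3 (0.51 log units; beyond the scatter)), although one heavy atom simply replaces another. The step from the 3-methoxyphenyl to the 4-chlorophenyl stays within the scatter (a 1.5-fold higher number from compound 1 to compound 3 (0.17 log units; within the scatter)), so the high number of compound 2 does not go with every 4-substituted phenyl ring in this short series. Nothing available explains why chloro and methyl differ here.

From the compounds shown here alone, it remains open whether the methoxy group would give a similar number on the carbon that holds the chloro in compound 3, which would separate the effect of the group from that of its place. How fluoro, bromo, trifluoromethyl or an amine would behave on that carbon is also unknown.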